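The source may report more compounds than this note shows. Statements on the series, on what has been measured and on what is new or still open speak of the compounds shown alone.

Of the compounds shown here, three sharing one core have been measured in an in vivo functional assay on the whole organism (MDA-MB-435 cells, Homo sapiens) for antiproliferative activity; on this read-out lower numbers stand for stronger inhibition and higher numbers for weaker inhibition. Compound 1 `CO[C@@H](C(=O)NC1CC[C@@H](OC(=O)c2ccccc2)CNC1=O)[C@H](O)[C@@H](O)[C@H](O)/C=C/C(C)(C)C` gives 370 nM, compound 3 `CO[C@@H](C(=O)NC1CC[C@@H](OC(=O)C2CCCCC2)CNC1=O)[C@H](O)[C@@H](O)[C@H](O)/C=C/C(C)(C)C` gives 4 nM, and compound 2 `CO[C@@H](C(=O)NC1CC[C@@H](OC(=O)Cc2cccnc2)CNC1=O)[C@H](O)[C@@H](O)[C@H](O)/C=C/C(C)(C)C` gives 5850 nM, the highest of the three numbers and so the weakest inhibition.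

Compound 4 `CCCCCCCCCCCCCC(=O)O[C@@H]1CCC(NC(=O)[C@H](OC)[C@H](O)[C@@H](O)[C@H](O)/C=C/C(C)(C)C)C(=O)NC1` has dodecyl in place of pyridin-3-yl on a saturated chain carbon bound to a carbonyl carbon.

The closest guide is the swap to cyclohexyl, a group of carbon and hydrogen only, which shows a 1500-fold lower number from compound 2 to compound 3 (3.17 log units; beyond the scatter). Phenyl, also free of nitrogen, points the same way, since the change away from it shows a 16-fold higher number from compound 1 to compound 2 (1.20 log units; beyond the scatter). However, these two ring groups differ widely from each other, with a 93-fold lower number from compound 1 to compound 3 (1.97 log units; beyond the scatter), and no measured compound carries a long chain, so the size of the step remains uncertain.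

The expected change is a large one toward a lower number, a 290-fold lower number from compound 2 to compound 4 (2.47 log units; beyond the scatter). For compound 4 the estimated value is 20 nM, with an expected range of 3 nM to 150 nM.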

Compound 4, half-maximal inhibitory concentration: < 10 nM
Compound 4: no number, only a limit (the forecaster's own chance of this, stated with the estimate: 3%); at least 2.0-fold (0.30 log units) between middle value and limit.
By their numbers in this assay, from the lowest: compound 3; then compound 1; then compound 2.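

For the compounds shown here, at this place, on a saturated chain carbon bound to a carbonyl carbon, the earlier compounds all carried a ring, so they could not show what a group with no ring would do. In this assay, dodecyl in place of pyridin-3-yl gives an at least 580-fold lower number from compound 2 to compound 4 (2.76 log units; beyond the scatter), so a long open chain of carbon atoms can also go with strong inhibition here. The value of compound 4, < 10 nM, is a limit of the assay and not an exact number: the limit of < 10 nM in this assay, at which 1 of the 4 values shown sits.

The compounds shown leave open how chain length matters, for example whether a hexyl or an octadecyl chain, or a chain ending in an amine or a carboxylic acid, would give a similarly low number. Going by these compounds, the order of compound 4 and compound 3 also stays open.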